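The compounds below may be only part of what the source reports. "The series", "measured", "known", "first", "only" and "open" are said of these compounds alone.

Working notes on the series. Three compounds share one core and have been run in an ADME assay on Left cardiac atrium (Cavia porcellus); on this read-out lower numbers stand for an effect already at smaller amounts and higher numbers for an effect only at larger amounts of compound. Compound 1 `CCOC(=O)C1=C(C)NC(C)=C(C(=O)OCC)C1c1c(-c2ccc(OC(F)(F)F)cc2)nc2sc(Br)cn12` gives 93 nM. Compound 2 `CCOC(=O)C1=C(C)NC(C)=C(C(=O)OCC)C1c1c(-c2ccc([N+](=O)[O-])cc2)nc2sc(Cl)cn12` gives 1370 nM. Compound 3 `CCOC(=O)C1=C(C)NC(C)=C(C(=O)OCC)C1c1c(-c2cc(OC)ccc2OC)nc2sc(C)cn12` gives 250 nM, which is the second highest of the three numbers; its nearest neighbour is compound 1, at a lower number beyond the scatter, and the furthest is compound 2, at a higher number beyond the scatter. Among the measured compounds shown here, no two measured compounds differ in a single place, so no isolated step is available from the measured set.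

Compound 4 `CCOC(=O)C1=C(C)NC(C)=C(C(=O)OCC)C1c1c(-c2cc(OC)ccc2OC)nc2sc(Br)cn12` is not yet measured in this assay. It differs from compound 3 by bromo in place of methyl on an aromatic carbon. Compound 1 also carries bromo at that position and gives 93 nM, but its aryl substituent differs from that of compound 3, so that comparison does not isolate the change. For compound 4 a modest step toward a lower number is expected, of size a 1.7-fold lower number from compound 3 to compound 4 (0.22 log units; within the scatter), close to the edge of the usual scatter. Compound 4 is therefore estimated at 150 nM, with a range from 50 nM to 500 nM.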

Compound 4, half-maximal effective concentration: 26 nM
For compound 4 the middle estimate is 5.8-fold (0.76 log units) above the measured one; measured number below the stated range.
By their numbers in this assay, from the lowest: compound 4; then compound 1; then compound 3; then compound 2.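

In this assay, among the compounds shown here, bromo in place of methyl on the aromatic carbon next to the ring sulfur gives a 9.6-fold lower number from compound 3 to compound 4 (0.98 log units; beyond the scatter), the first isolated reading at this position, and it shows that this single-atom exchange alone moves the number substantially. With bromo held at that position, 2,5-dimethoxyphenyl in place of 4-(trifluoromethoxy)phenyl gives a 3.6-fold lower number from compound 1 to compound 4 (0.55 log units; beyond the scatter), so the aryl group also moves the number and the position does not act alone. Nothing available here accounts for either step.

The compounds shown leave open whether the step from methyl to bromo holds with other aryl groups, since only the 2,5-dimethoxyphenyl pair isolates it. They also leave open how a nitrile, an amine or a longer chain such as propyl would read at this position.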